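This account rests on a few compounds, and the source may have more. Where it says the series, first, only, none or still open, it means among the compounds named here.

Compound 1 `Nc1cc(N)c2nc(-c3ccccc3)c(Oc3ccc(Cl)c(Cl)c3)nc2c1` carries a 3,4-dichlorophenoxy group on the shared core. In a functional assay on A549 cells (Homo sapiens) for inhibition, read by sulforhodamine B assay, with a stated time of 48 h (on this read-out lower numbers stand for higher toxicity in this test and higher numbers for lower toxicity in this test), compound 1 gives < 100000 nM, which is a limit of the assay and not a number. Compound 3 `CCOC(=O)[C@H](CCC(=O)O)NC(=O)c1ccc(Oc2nc3cc(N)cc(N)c3nc2-c2ccccc2)cc1` gives in this assay < 100000 nM, again a limit. Compound 2 `COc1cc(CNc2nc3cc(N)cc(N)c3nc2-c2ccccc2)cc(OC)c1OC` gives in this assay < 50200 nM, also a limit. Among the measured compounds shown here, the measured values gather at the limit of < 100000 nM in this assay, at which 2 of the 3 values shown sit, and at the limit of < 50200 nM in this assay, at which 1 of the 3 values shown sits, so no step between measured compounds can be computed and compound 1 cannot be ranked against either neighbour; it stands with the others at the edge of what this assay reports.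

Compound 4 `Nc1cc(N)c2nc(-c3ccccc3)c(Oc3ccc(F)cc3)nc2c1` differs from compound 1 by 4-fluorophenyl in place of 3,4-dichlorophenyl on an oxygen on an aromatic ring. With every value known only as a limit, no direction for the change can be read from the data. The expected step of a number no lower from compound 1 to compound 4 (the limit leaves the size open) is therefore none beyond the scatter, an estimate rather than a derived number. Compound 4 is estimated at 100000 nM in this assay, within 30000 nM to 300000 nM, and is expected most likely to be reported again only as a limit.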

Compound 4, concentration lethal to 50% of the cells: 89100 nM
Beside the measured number, compound 4's estimate is 1.1-fold (0.05 log units) above it; the range from low to high includes it.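

Compound 4 has a numeric value, but compound 1 stands only as a limit of the assay, and no new step can be read from compound 1 to compound 4 in this assay. The compounds shown leave open the direction and size of the change from 3,4-dichlorophenoxy to 4-fluorophenoxy.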